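From isopentyl to butyl on a shared core

The source may report more compounds than this note shows. Statements on the series, on what has been measured and on what is new or still open speak of the compounds shown alone.

Compound 1 `CCCC1=C(OC)C(CCC)(CCC)C(=O)/C(=C(O)\C=C\c2ccc(I)cc2)C1=O` gives 1.1 uM
Compound 2 `CCCC1=C(OCCC(C)C)C(CCC)(CCC)C(=O)/C(=C(O)\C=C\c2ccccc2)C1=O` gives 15.3 uM
Compound 3 `COC1=C(CC(C)C)C(=O)/C(=C(O)/C=C/c2ccccc2)C(=O)C1(CC(C)C)CC(C)C` gives 7.5 uM

In a functional assay on HCT-8 cells (Homo sapiens) for antiproliferative activity, read by sulforhodamine B assay, with a stated time of 3 days (a lower number here means that less compound is needed, a higher number that more compound is needed for the effect), compound 2 has the highest number of the three, standing at 15.3 uM on this read-out. Its nearest neighbour is compound 3 at 7.5 uM and its furthest is compound 1 at 1.1 uM on the same scale. Both gaps lie beyond the scatter.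

Compound 4 `CCCCOC1=C(CCC)C(=O)/C(=C(O)/C=C/c2ccccc2)C(=O)C1(CCC)CCC` has not yet been measured. It differs from compound 2 by hydrogen in place of methyl on a saturated chain carbon bound to two saturated chain carbons in a single place. That is hydrogen in place of methyl on a saturated chain carbon bound to two saturated chain carbons, so isopentyl becomes butyl.

Among the measured compounds shown here, no step between the measured compounds speaks directly to this change. The estimate therefore starts from compound 2 at 15.3 uM as its anchor. No step beyond the scatter is expected in this assay, with only a slight lean toward a lower number. The expected shift is a 1.4-fold lower number from compound 2 to compound 4 (0.14 log units; within the scatter) and it stays modest. For compound 4 the estimated value is 11 uM with an expected range from 5 uM to 24 uM on this read-out.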

Compound 4, concentration for half-maximal effect: 8.7 uM
Estimate against measurement, compound 4: 1.3-fold (0.10 log units) above; measured number inside the range.
By their numbers in this assay, from the lowest: compound 1; then compounds 3, 4 and 2 (each within the scatter of the next, the first and the last beyond it).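

With the shared core otherwise unchanged, hydrogen in place of methyl on a saturated chain carbon bound to two saturated chain carbons, which turns isopentyl into butyl, gives a 1.8-fold lower number from compound 2 to compound 4 (0.25 log units; within the scatter) in this assay. This is the only step among the compounds shown that isolates a single place, and it shows that isopentyl and butyl cannot be told apart at this position in this read-out, since the step stays within the usual scatter of repeated measurements. Nothing measured alongside these compounds bears on this result, so the step stands here as an observation with no explanation attached.

The compounds shown leave open whether a longer chain such as hexyl, or a chain carrying an amine or a carboxylic acid, would give a step beyond the scatter in place of butyl. They also leave open whether the same exchange of methyl for hydrogen would read the same way on a compound carrying the other differences seen in compound 1, such as its iodine atom.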